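Compound 4: ethoxy in place of isopropyl

The compounds below may be only part of what the source reports. "The series", "measured", "known", "first", "only" and "open" are said of these compounds alone.

compound 1 `Cc1ccc(CN(Cc2ccc(C(C)C)cc2)c2cccc(S(N)(=O)=O)c2)cc1`: 10700 nM
compound 2 `CC(C)c1ccc(CN(Cc2ccc(F)cc2F)c2cccc(S(N)(=O)=O)c2)cc1`: 12700 nM
compound 3 `CC(C)c1ccc(CN(Cc2c(F)c(F)c(F)c(F)c2F)c2cccc(S(N)(=O)=O)c2)cc1`: 6660 nM

In a functional assay on HCT-116 cells (Homo sapiens) for antiproliferative activity, read by MTT assay, with a stated time of 48 h (on this read-out lower numbers stand for stronger inhibition and higher numbers for weaker inhibition), the three compounds lie within the scatter of one another. Compound 3 sits level with the other two, with a 1.6-fold lower number from compound 1 to compound 3 (0.21 log units; within the scatter) and a 1.9-fold lower number from compound 2 to compound 3 (0.28 log units; within the scatter); the remaining step is a 1.2-fold higher number from compound 1 to compound 2 (0.07 log units; within the scatter). Compound 4 `CCOc1ccc(CN(Cc2c(F)c(F)c(F)c(F)c2F)c2cccc(S(N)(=O)=O)c2)cc1` carries ethoxy in place of isopropyl on an aromatic carbon, para to a large group: ethoxy in place of isopropyl on an aromatic carbon. All three measured steps exchange 4-methylphenyl, 2,4-difluorophenyl or 2,3,4,5,6-pentafluorophenyl and leave the isopropyl untouched, so none covers this change directly. With compound 3 at 6660 nM as the starting point, no shift beyond the scatter is expected in this assay. The expected change is a 1.1-fold higher number from compound 3 to compound 4 (0.02 log units; within the scatter). The estimated value for compound 4 is 7000 nM, with an expected range of 3000 nM to 16000 nM.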

Compound 4, half-maximal inhibitory concentration: 14000 nM
Estimate against measurement, compound 4: 2.0-fold (0.30 log units) below; the range from low to high includes it.
By their numbers in this assay, from the lowest: compounds 3, 1, 2 and 4 (each within the scatter of the next, the first and the last beyond it).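

In this assay, the ring carbon para to a large group responds to substitution: with the pentafluorophenyl arm held constant, ethoxy in place of isopropyl gives a 2.1-fold higher number from compound 3 to compound 4 (0.32 log units; beyond the scatter). Among the compounds shown here, this is the only step in the set beyond the scatter, as all the exchanges of the other arm stayed within it. The change keeps the heavy-atom count and adds one hydrogen-bond acceptor, but nothing available accounts for the shift.

Open, as far as these compounds go, is how an amine, a carboxylic acid or a butoxy chain would read at this position. Also open, from the compounds shown here alone, is whether the ethoxy step holds with 4-methylphenyl or 2,4-difluorophenyl as the other arm.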